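This account rests on a few compounds, and the source may have more. Where it says the series, first, only, none or still open, it means among the compounds named here.

Three compounds have been measured in a functional assay on MCF7 cells (Homo sapiens) for cytotoxicity, read by MTT assay, with a stated time of 48 h; a lower number here means a stronger inhibitor, a higher number a weaker inhibitor:

compound 1 `CC(=NNC(=S)Nc1ccccc1F)c1ccccn1`: 0.39 nM
compound 2 `CC(=NNC(=S)Nc1ccccc1)c1ccccn1`: 0.18 nM
compound 3 `C/C(=N\NC(=S)Nc1ccccc1)c1ccccn1`: 0.18 nM

Compound 2 and compound 3 share everything in their structures; (the two compounds have the same atoms and bonds; at least one stereo element is drawn with a configuration in one of them and without one in the other: 1 of 1 stereo elements differ; a double bond is drawn without a configuration in compound 2 and E in compound 3). In this assay there is no change at the digits printed from compound 2 to compound 3 (within the scatter), which fits (the fact that one of compounds 2 and 3 is drawn with a defined configuration and the other without, at the place where they differ). The step from compound 2 to compound 1 is fluoro in place of hydrogen on an aromatic carbon; in this assay it gives a 2.2-fold higher number from compound 2 to compound 1 (0.34 log units; beyond the scatter).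

Compound 4 `C/C(=N\NC(=S)Nc1ccc(F)cc1)c1ccccn1` has not yet been measured. It differs from compound 3 in that (fluoro in place of hydrogen on an aromatic carbon). This is the same kind of change as that from compound 2 to compound 1, but not the same: in compound 1 the fluoro sits ortho to a large group, in compound 4 para to a large group. Among the compounds with values here, only one example of this change exists among the measured compounds, so the expectation rests on that single step, a 2.2-fold higher number from compound 2 to compound 1 (0.34 log units; beyond the scatter). For compound 4 a step of a 1.8-fold higher number from compound 3 to compound 4 (0.25 log units; within the scatter) from compound 3 is expected in this assay. Compound 4 is accordingly estimated at 0.32 nM, between 0.12 nM and 0.9 nM.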

Compound 4, half-maximal inhibitory concentration: 1.2 nM
Beside the measured number, compound 4's estimate is 3.8-fold (0.57 log units) below it; the whole stated range lies below it.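

In this assay, fluoro in place of hydrogen on an aromatic carbon, here para to a large group, gives a 6.7-fold higher number from compound 3 to compound 4 (0.82 log units; beyond the scatter). The direction of the earlier step carries over to this one but its size does not, and the gap between the two is larger than repeated measurements would account for: the same change on two cores in this assay, a 2.2-fold higher number (0.34 log units; beyond the scatter) from compound 2 to compound 1 and a 6.7-fold higher number (0.82 log units; beyond the scatter) from compound 3 to compound 4, 3.1-fold (0.49 log units) apart, beyond the scatter of two such steps. The two steps also differ in where the fluoro sits and in how the double bond is drawn, and the data do not tell which of these, if either, lies behind the gap, nor can two steps set a rule for this change across the series.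

The compounds shown leave open how chloro, methoxy or an amine would fare in place of fluoro on the same aromatic ring. They also leave open what a longer chain in place of the methyl group would do to the number in this assay.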